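The source may report more compounds than this note shows. Statements on the series, on what has been measured and on what is new or still open speak of the compounds shown alone.

Measured so far in a functional assay on PC-3 cells (Homo sapiens) for inhibition, read by sulforhodamine B assay; a lower number here means a stronger inhibitor of growth, a higher number a weaker inhibitor of growth:
- Compound 1 `COc1ccc(-c2ccc(-c3ccc(-c4nc5ccccc5[nH]4)cc3)cc2)cc1` gives 100000 nM
- Compound 2 `Oc1cccc2[nH]c(-c3ccc(-c4ccc(-c5ccccc5)cc4)cc3)nc12` gives 1240 nM
- Compound 3 `Oc1ccc(-c2ccc(-c3ccc(-c4nc5c(O)cccc5[nH]4)cc3)cc2)cc1` gives 190 nM

Compound 3 at 190 nM has the lowest of the three numbers. Compound 4 `COc1ccc(-c2ccc(-c3ccc(-c4nc5c(O)cccc5[nH]4)cc3)cc2)cc1` differs from it by methyl in place of hydrogen on an oxygen on an aromatic ring as methyl in place of hydrogen on an oxygen on an aromatic ring, so 4-hydroxyphenyl becomes 4-methoxyphenyl. The measured step that bears on this is a 6.5-fold lower number from compound 2 to compound 3 (0.81 log units; beyond the scatter) for hydroxy in place of hydrogen on an aromatic carbon, and compound 4 methylates that same hydroxy. Compound 1 also carries 4-methoxyphenyl and gives 100000 nM but differs from compound 4 elsewhere too. A step of similar size toward a higher number is therefore expected in this assay for this change. Compound 4 is expected at 1000 nM (estimated range 250 nM to 6000 nM). The estimated step is a 5.3-fold higher number from compound 3 to compound 4 (0.72 log units; beyond the scatter) overall.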

Compound 4, concentration for 50% growth inhibition: 6610 nM
Estimate against measurement, compound 4: 6.6-fold (0.82 log units) below; measured number outside the range, above it.
By their numbers in this assay, from the lowest: compound 3; then compound 2; then compound 4; then compound 1.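

In this assay, methyl in place of hydrogen on the oxygen of 4-hydroxyphenyl proves a large penalty (a 35-fold higher number from compound 3 to compound 4 (1.54 log units; beyond the scatter)). 4-Methoxyphenyl even gives a higher number than the unsubstituted phenyl (a 5.3-fold higher number from compound 2 to compound 4 (0.73 log units; beyond the scatter)), so at this position methoxy does worse than hydrogen, while hydroxy does better. Hydroxy in place of hydrogen on an aromatic carbon also lowers the number with 4-methoxyphenyl present (a 15-fold lower number from compound 1 to compound 4 (1.18 log units; beyond the scatter)), and the gain is comparable on both cores: the same change on two cores in this assay, a 6.5-fold lower number (0.81 log units; beyond the scatter) from compound 2 to compound 3 and a 15-fold lower number (1.18 log units; beyond the scatter) from compound 1 to compound 4, 2.3-fold (0.37 log units) apart, within the scatter of two such steps.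

The compounds shown leave open whether an amine or a carboxylic acid at this position would match hydroxy. They also leave open how a longer chain on the oxygen, such as ethoxy, would compare with methoxy.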